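The compounds below may be only part of what the source reports. "The series", "measured", "known", "first", "only" and "open" are said of these compounds alone.

The series is held together by a common diene acid skeleton, and a physicochemical assay for lipophilicity (on this read-out higher numbers stand for higher lipophilicity and lower numbers for lower lipophilicity), is the only read-out available. Compound 1 `CC(/C=C/CC(C)CCCC(C)C)=C\C(=O)OCc1ccccc1` gives 7.87 in this assay, and compound 3 `C=CCSC(=O)/C=C(C)/C=C/CC(C)CCCC(C)C` gives 7.97. For the measured compounds named here, the one step between measured neighbours, a number 0.10 log units higher from compound 1 to compound 3 (within the scatter), shows that swapping one carbonyl substituent for another of similar size left the number essentially where it was. Going by the values given here, compound 2 `COC(C)(C)CCCC(C)C/C=C/C(C)=C/C(=O)OC1CCC1` gives 6.44 in this assay, the lowest of the three values; its gap to compound 1 and to compound 3 is beyond the scatter in each case, though no single-point step connects it to either.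

The step to compound 4 `COC(C)(C)CCCC(C)C/C=C/C(C)=C/C(=O)CC(C)C` is isobutyl in place of cyclobutyloxy on a carbonyl carbon. Among the compounds with values here, no measured step describes this change; the one from compound 1 to compound 3 is the nearest analogy, since it also sits on the carbonyl carbon, and it was flat. Here an oxygen acceptor leaves and a four-carbon chain enters in place of a four-carbon ring, so a modest upward step in this assay is expected. The step from compound 2 to compound 4 is estimated as a number 0.46 log units higher from compound 2 to compound 4 (beyond the scatter). Compound 4 is therefore expected to give about 6.9, in the range 6.4 to 7.4.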

Compound 4, partition coefficient: 6.02
Compound 4: the middle estimate sits 0.88 log units above what was measured; measured number below the stated range.
By their numbers in this assay, from the lowest: compound 4; then compound 2; then compounds 1 and 3 (each within the scatter of the next).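

In this assay, for the compounds shown here, the carbonyl carbon no longer looks like a place where exchanges leave the number unchanged: a number 0.42 log units lower from compound 2 to compound 4 (beyond the scatter) when isobutyl enters in place of cyclobutyloxy, whereas the only earlier step at this place was a number 0.10 log units higher from compound 1 to compound 3 (within the scatter) when allylsulfanyl entered in place of benzyloxy. This exchange removes the four-membered ring and the hydrogen-bond acceptor of the leaving group together, and in this one pair the number goes down rather than up, so the loss of both does not bring a higher value here. Nothing measured alongside these numbers accounts for the direction of the step.

The two differences travel together in this single pair, so the compounds shown leave open whether the lower number goes with the oxygen or with the ring; a cyclobutyl group or an isobutyloxy group on the same carbonyl carbon would separate them. From the compounds shown here alone, it also remains open whether the step carries over to the skeleton of compound 1 and compound 3, which lacks the methoxy group of compound 2 and compound 4.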